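This account rests on a few compounds, and the source may have more. Where it says the series, first, only, none or still open, it means among the compounds named here.

Working notes on the series. Two compounds carry numbers in a functional assay on the whole organism with Mus musculus as the target; a lower number here means that less compound is needed, a higher number that more compound is needed for the effect. Compound 1 `c1ccc(N2N=NCC2c2ccncc2)cc1` gives 107 mg/kg in this assay. Compound 2 `c1ccc(-n2nncc2-c2ccncc2)cc1` gives 73.7 mg/kg in this assay; of the two numbers this is the lower, but the gap to compound 1 lies within the usual scatter, so the two compounds stand together rather than in an order. Compound 3 `FC(F)(F)c1cccc(-n2nncc2-c2ccncc2)c1` has not yet been measured in this assay. It differs from compound 2 in one place: trifluoromethyl in place of hydrogen on an aromatic carbon, a trifluoromethyl in place of hydrogen on an aromatic carbon of the six-membered aromatic ring of carbon only, meta to a large group. Within the data shown here, no pair of measured compounds differs by such a change, so the series gives no size for this step. The step from compound 2 to compound 3 is expected to stay within the scatter, a 1.2-fold lower number from compound 2 to compound 3 (0.09 log units; within the scatter). Compound 3 is estimated at 60 mg/kg, with a range from 25 mg/kg to 150 mg/kg.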

Compound 3, dose for half-maximal effect: 44.7 mg/kg
The estimate for compound 3 lay 1.3-fold (0.13 log units) above the measured number, and the stated range covers the measured number.
By their numbers in this assay, from the lowest: compounds 3, 2 and 1 (each within the scatter of the next, the first and the last beyond it).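

Trifluoromethyl in place of hydrogen on an aromatic carbon, meta to a large group, now has a measured size in this assay as a 1.6-fold lower number from compound 2 to compound 3 (0.22 log units; within the scatter) and so gives no readable change. This place on the six-membered aromatic ring of carbon only therefore accepts trifluoromethyl, with its 4 heavy atoms, without a shift beyond the scatter, which compounds 1 and 2, both with hydrogen there, could not show. No measurement at hand bears on why the step has this size.

The compounds shown leave open whether an amine, a carboxylic acid or a longer chain at this place would give a step beyond the scatter. They also leave open whether trifluoromethyl would give a similar step on the core of compound 1 or at another carbon of this ring.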